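The source may report more compounds than this note shows. Statements on the series, on what has been measured and on what is new or still open speak of the compounds shown alone.

In a functional assay on HepG2 cells (Homo sapiens) for inhibition, read by MTT assay, with a stated time of 3 days (on this read-out lower numbers stand for stronger inhibition and higher numbers for weaker inhibition), compound 1 (`CC[C@H](C)[C@@H](NCC(=O)NNC(=O)COc1ccc(-c2nc3ccccc3s2)cc1OC)C(=O)O`) gives 3990 nM and compound 2 (`COc1cc(-c2nc3ccccc3s2)ccc1OCC(=O)NNC(=O)CN[C@@H](CS)C(=O)O`) gives 3120 nM and compound 3 (`COc1cc(-c2nc3ccccc3s2)ccc1OCC(=O)NNC(=O)CN[C@@H](CS(=O)(=O)O)C(=O)O`) gives 3690 nM as its half-maximal inhibitory concentration. Compound 3 therefore lies within the usual scatter of both other compounds, and no order can be read among the three.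

Compound 4 (`CCOC(=O)[C@@H](NCC(=O)NNC(=O)COc1ccc(-c2nc3ccccc3s2)cc1OC)[C@@H](C)CC`) has 1-(ethoxycarbonyl)-2-methylbutyl in place of 1-carboxy-2-sulfoethyl on an amine nitrogen. The measured steps that bear on this change are small: a 1.1-fold lower number from compound 1 to compound 3 (0.03 log units; within the scatter) for 1-carboxy-2-sulfoethyl in place of 1-carboxy-2-methylbutyl and a 1.2-fold higher number from compound 2 to compound 3 (0.07 log units; within the scatter) for sulfo in place of sulfanyl. Both lie within the scatter. Going by the values given here, no measured compound carries an ethoxycarbonyl group, so that part of the change has no measured guide.

In this assay no step beyond the scatter is expected, and the range must stay wide. The expected change is a 1.2-fold lower number from compound 3 to compound 4 (0.09 log units; within the scatter) as an estimate only. Compound 4 is estimated at 3000 nM (expected range 1000 nM to 8000 nM).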

Compound 4, half-maximal inhibitory concentration: 3460 nM
Compound 4: middle estimate off by 1.2-fold (0.06 log units), on the low side; low and high end bracket the measured number.
By their numbers in this assay, from the lowest: compounds 2, 4, 3 and 1 (each within the scatter of the next).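

Going by these compounds alone, on the amine nitrogen, this assay gives a 1.1-fold lower number from compound 3 to compound 4 (0.03 log units; within the scatter) and a 1.1-fold higher number from compound 2 to compound 4 (0.04 log units; within the scatter) and also a 1.2-fold lower number from compound 1 to compound 4 (0.06 log units; within the scatter), so even 1-(ethoxycarbonyl)-2-methylbutyl, the first group here without a carboxy group, leaves compound 4 among the other three. Compared with 1-carboxy-2-sulfoethyl, this group has no hydrogen-bond donors and no sulfur, yet the number stays within the scatter, so none of the four groups tried on this nitrogen separates from the others. No measurement on hand explains this lack of separation.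

From the compounds shown here alone, whether a group with a second amine, a phenyl ring or a longer chain on this nitrogen would move the number beyond the scatter remains open. All four compounds share the same core, so what its parts contribute cannot be read from them.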